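The source may hold more compounds than are shown below. What is called first, only, known or untested is meant among the compounds shown, and "the series" means these compounds.

Three compounds of the shared core have been run in a functional assay on CCRF-CEM cells (Homo sapiens) for antiproliferative activity, read by MTT assay, with a stated time of 24 h, tested at 12.5 uM; on this read-out lower numbers stand for a stronger effect and higher numbers for a weaker effect at the one concentration tested. Compound 1 `OC(CCn1nc2c(Br)c(Br)c(Br)c(Br)c2n1)c1ccc(F)cc1` gives 110% and compound 2 `OC(CCn1nc2c(Br)c(Br)c(Br)c(Br)c2n1)c1cccc(Cl)c1` gives 110%; the step of no change at the digits printed from compound 1 to compound 2 (within the scatter). Compound 3 `C[C@H](O)CCn1nc2c(Br)c(Br)c(Br)c(Br)c2n1` gives 126%, the highest of the three, beyond the scatter relative to both compound 1 and compound 2. Compound 4 `CC(O)CCn1nc2c(Br)c(Br)c(Br)c(Br)c2n1` comes next: the two compounds have the same atoms and bonds; at least one stereo element is drawn with a configuration in one of them and without one in the other: 1 of 1 stereo elements differ; a stereocentre at a saturated chain carbon is drawn S in compound 3 and without a configuration in compound 4. Among the measured compounds shown here, no measured step concerns a stereocentre drawn with and without a configuration; the single measured step changes an aromatic group and lies within the scatter, so it offers no direction for this change. The step in this assay from compound 3 to compound 4 is therefore expected to be small, a number 8 percentage points lower from compound 3 to compound 4 (within the scatter), with compound 3 as the only anchor. Compound 4 is estimated at 118%, between 100% and 136%.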

Compound 4, a percentage reported as activity, at one concentration (the size of the read-out at that concentration, not a potency): 106%
Estimate against measurement, compound 4: 12 percentage points above; the range from low to high includes it.
By their numbers in this assay, from the lowest: compounds 4, 1 and 2 (each within the scatter of the next); then compound 3.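

In this assay the series shows a number 20 percentage points lower from compound 3 to compound 4 (beyond the scatter), its first step beyond the scatter, with no change of atoms or bonds. Methyl in place of the aromatic groups gives a number 4 percentage points lower from compound 2 to compound 4 (within the scatter) and a number 4 percentage points lower from compound 1 to compound 4 (within the scatter), so methyl, 3-chlorophenyl and 4-fluorophenyl on this carbon are not told apart here. The larger step rests on a difference in drawing alone: the fact that one of compounds 3 and 4 is drawn with a defined configuration and the other without, at the place where they differ.

From the compounds shown here alone, what compound 4 holds at the stereocentre, and how the R configuration would read, stays open. So does the effect of an amine in place of the hydroxyl, or of a longer chain.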